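A few compounds are considered here, and "the series" means these few. Any claim that something is new, unique, unknown or untested is made for them only; others in the source may bear on it.

In a functional assay on PC-3 cells (Homo sapiens) for antiproliferative activity, read by MTT assay, with a stated time of 48 h (a lower number here means a stronger inhibitor, a higher number a weaker inhibitor), compound 1 `COc1ccc(CN(C(=O)CSc2nc3ccccc3s2)c2cc(OC)c(OC)c(OC)c2)cc1N=[N+]=[N-]` gives 14400 nM. Compound 3 `COc1ccc(CN(C(=O)CSc2nc3cc(Cl)ccc3s2)c2cc(OC)c(OC)c(OC)c2)cc1O`, at 11200 nM, lies within the scatter of that value, while compound 2 `COc1ccc2nc(SCC(=O)N(Cc3ccc(OC)c(O)c3)c3cc(OC)c(OC)c(OC)c3)sc2c1`, at 4110 nM, is clearly the stronger inhibitor of the pair with compound 1. Compound 4 `COc1cc(N(Cc2ccc(Cl)cc2)C(=O)CSc2nc3ccccc3s2)cc(OC)c1OC` changes one group of compound 1, the benzyl group on the amide-type nitrogen: 4-chlorophenyl in place of 3-azido-4-methoxyphenyl on a saturated chain carbon bound to an amide-type nitrogen. Going by the values given here, the only measured step, a 2.7-fold higher number from compound 2 to compound 3 (0.44 log units; beyond the scatter), is modest and concerns a different group, the one on a sulfur, so it offers only a rough guide to size. A change of similar modest size or less, with no clear direction, is therefore expected in this assay. The expected result is a 1.4-fold lower number from compound 1 to compound 4 (0.16 log units; within the scatter). The estimate for compound 4 is 10000 nM, with a range of 3500 nM to 30000 nM.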

Compound 4, half-maximal inhibitory concentration: > 80000 nM
Compound 4 ended at the assay's limit; the forecaster's own chance of this, stated with the estimate: 10%; at least 8.0-fold (0.90 log units) between middle value and limit.
By their numbers in this assay, from the lowest: compound 2; then compounds 3 and 1 (each within the scatter of the next). At a limit, above all of these: compound 4.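

The earlier compounds shown here showed a step only on the sulfur side; this one shows that the group on a saturated chain carbon bound to an amide-type nitrogen also matters in this assay, where 4-chlorophenyl in place of 3-azido-4-methoxyphenyl gives an at least 5.5-fold higher number from compound 1 to compound 4 (0.74 log units; beyond the scatter). Compound 4 sits at a limit of the assay, so the full size of this step cannot be read, because its value is not a number: the limit of > 80000 nM in this assay, at which 1 of the 4 values shown sits.

Open, from the compounds shown here alone, is whether losing the azido group, losing the methoxy group or gaining the chlorine drives the change. Also open, going by these compounds, is how a plain phenyl or an aminophenyl group would read in this place.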